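The source may report more compounds than this note shows. Statements on the series, on what has been measured and on what is new or still open speak of the compounds shown alone.

Measured so far in a functional assay on LOX IMVI cells (Homo sapiens) for cytotoxicity, read by MTT assay, with a stated time of 24 h; a lower number here means a stronger inhibitor, a higher number a weaker inhibitor:
compound 1, `COc1cc(-c2nc(-c3ccccc3)[nH]c2-c2ccnc(NCCCNS(=O)(=O)c3cccc(F)c3)n2)ccc1F`: 900 nM
compound 2, `COc1cc(-c2nc(-c3ccccc3)[nH]c2-c2ccnc(NCCCNS(=O)(=O)c3cccc4ccccc34)n2)ccc1F`: 14900 nM

Going by the values given here, compound 2 gives the higher of the two numbers in this assay; the only measured step is a 17-fold higher number from compound 1 to compound 2 (1.22 log units; beyond the scatter), a change of naphthalen-1-yl in place of 3-fluorophenyl on a sulfonyl sulfur. Compound 3, `O=S(=O)(NCCCNc1nccc(-c2[nH]c(-c3ccccc3)nc2-c2ccc(F)c(O)c2)n1)c1cccc2ccccc12`, keeps that naphthalen-1-yl and differs from compound 2 only by hydrogen in place of methyl on an oxygen on an aromatic ring, that is methoxy to hydroxy. Among the compounds with values here, no measured step touches this oxygen, so the single known step offers no guidance here. With nothing to argue otherwise, the expected step is none beyond the scatter, a 1.1-fold lower number from compound 2 to compound 3 (0.03 log units; within the scatter). Compound 3 is therefore estimated at 14000 nM, range 4000 nM to 50000 nM.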

Compound 3, half-maximal inhibitory concentration: 3710 nM
Estimate against measurement, compound 3: 3.8-fold (0.58 log units) above; the measured number lies below the stated range.
By their numbers in this assay, from the lowest: compound 1; then compound 3; then compound 2.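

In this assay, the change from 4-fluoro-3-methoxyphenyl to 4-fluoro-3-hydroxyphenyl gives a 4.0-fold lower number from compound 2 to compound 3 (0.60 log units; beyond the scatter) in the naphthalen-1-yl compounds. The series is therefore sensitive at this oxygen as well as on the sulfonyl sulfur, which the earlier step could not show. Nothing available accounts for this step. Going by these compounds, it remains open whether removing this methyl has a similar effect with 3-fluorophenyl on the sulfonyl sulfur. Also open, on these data alone, is how an ethoxy group or an amine would read at this place.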